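The source may report more compounds than this note shows. Statements on the series, on what has been measured and on what is new or still open speak of the compounds shown alone.

Working notes on the series. Three compounds share one core and carry different groups on the triple-bonded carbon. Compound 1 `O=C1c2ccc(C#Cc3ccccc3Cl)nc2CCN1C1CCCC1` gives 393 nM in a functional assay on HEK293 cells for positive allosteric modulation of metabotropic glutamate receptor 5 (Homo sapiens), read by FLIPR and calcium flux; on this read-out lower numbers stand for an effect already at smaller amounts and higher numbers for an effect only at larger amounts of compound. Compound 2 `COc1cccc(C#Cc2ccc3c(n2)CCN(C2CCCC2)C3=O)c1` gives 462 nM in this assay, and compound 3 `O=C1c2ccc(C#Cc3cccnc3)nc2CCN1C1CCCC1` gives 748 nM in this assay. Compound 3 has the highest of the three numbers, but every step to it lies within the scatter: a 1.9-fold higher number from compound 1 to compound 3 (0.28 log units; within the scatter) and a 1.6-fold higher number from compound 2 to compound 3 (0.21 log units; within the scatter), as does a 1.2-fold higher number from compound 1 to compound 2 (0.07 log units; within the scatter). The three aryl groups on the triple-bonded carbon therefore cannot be told apart on these data.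

Compound 4 `O=C1c2ccc(C#Cc3cccnc3)nc2CCN1C1CCCCC1` is not yet measured. It differs from compound 3 in this: cyclohexyl in place of cyclopentyl on an amide-type nitrogen in a ring. None of the three measured steps touches the amide-type nitrogen; all of them change the aryl group on the triple-bonded carbon, and each stayed within the scatter. Going by the values given here, there is no measured step that bears on the change from compound 3 to compound 4, so the expectation rests on the absence of any contrary evidence rather than on a precedent. For compound 4 the step from compound 3 is expected to be a 1.0-fold higher number from compound 3 to compound 4 (0.00 log units; within the scatter), that is, no change beyond the scatter in this assay. Compound 4 is estimated at 750 nM in this assay, with a range from 300 nM to 2000 nM that is deliberately wide, since nothing measured here speaks to this position.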

Compound 4, half-maximal effective concentration: 387 nM
Compound 4: middle estimate off by 1.9-fold (0.29 log units), on the high side; low and high end bracket the measured number.
By their numbers in this assay, from the lowest: compounds 4, 1, 2 and 3 (each within the scatter of the next).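

Going by these compounds alone, this is the first step at the amide-type nitrogen in a ring, and in this assay cyclohexyl in place of cyclopentyl gives a 1.9-fold lower number from compound 3 to compound 4 (0.29 log units; within the scatter), so this change, like the changes on the triple-bonded carbon, stays inside the scatter and the four compounds cannot be told apart at either position. The change is seen here only with pyridin-3-yl on the triple-bonded carbon, so the result describes this one pair and sets no trend for ring size on that nitrogen. No measured evidence bears on this result.

On these data alone, it remains open whether cyclohexyl in place of cyclopentyl reads the same with 2-chlorophenyl or 3-methoxyphenyl on the triple-bonded carbon. Also open, as far as these compounds go, is how the amide-type nitrogen responds to groups other than these two carbon rings, such as a cyclobutyl ring, an open isopropyl chain, a benzyl group or a piperidine ring carrying an amine, and whether any of them would give a step beyond the scatter.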